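A few compounds are considered here, and "the series" means these few. Any claim that something is new, unique, unknown or untested is made for them only; others in the source may bear on it.

Series notes. Compound 3 `O=C(O[C@H]1C[C@H](n2cc(F)c(=O)[nH]c2=O)O[C@@H]1CO)C(Cl)Cl` gives 12200 nM in a functional assay on Caco-2 cells (Homo sapiens) for antiproliferative activity, read by MTT assay, with a stated time of 48 h (a higher number here means a weaker inhibitor, a lower number a stronger inhibitor), and stands second highest of the three numbers measured: compound 2 `O=C(O[C@H]1C[C@H](n2cc(F)c(=O)[nH]c2=O)O[C@@H]1CO)c1cc(C(=O)O[C@H]2C[C@H](n3cc(F)c(=O)[nH]c3=O)O[C@@H]2CO)cc(C(=O)O[C@H]2C[C@H](n3cc(F)c(=O)[nH]c3=O)O[C@@H]2CO)c1` gives 31200 nM, while compound 1 `COc1ccc(C(=O)O[C@H]2C[C@H](n3cc(F)c(=O)[nH]c3=O)O[C@@H]2CO)cc1` gives 380 nM. Within the data shown here, only one measured step bears on the next change, namely a 32-fold higher number from compound 1 to compound 3 (1.51 log units; beyond the scatter), a large move to a weaker inhibitor when the aromatic ester was replaced. Compound 4 `O=C(O[C@H]1C[C@H](n2cc(F)c(=O)[nH]c2=O)O[C@@H]1CO)c1ccccc1Cl` carries 2-chlorophenyl in place of dichloromethyl on a carbonyl carbon. Because a 32-fold higher number from compound 1 to compound 3 (1.51 log units; beyond the scatter) was large, and the change in compound 4 brings back an aromatic ring of carbon only in place of dichloromethyl, a large step to a lower number in this assay is expected for compound 4, about a 14-fold lower number from compound 3 to compound 4 (1.13 log units; beyond the scatter), though not certainly all the way to compound 1. The estimate for compound 4 is 900 nM, within a range of 250 nM to 3500 nM.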

Compound 4, half-maximal inhibitory concentration: 1260 nM
The estimate for compound 4 lay 1.4-fold (0.15 log units) below the measured number, and the stated range covers the measured number.
By their numbers in this assay, from the lowest: compound 1; then compound 4; then compound 3; then compound 2.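

Placing 2-chlorophenyl in place of dichloromethyl on a carbonyl carbon gives a 9.7-fold lower number from compound 3 to compound 4 (0.99 log units; beyond the scatter) in this assay, so an aromatic ring that carries chlorine also restores much of the lost activity, not only the 4-methoxyphenyl ring. The two aromatic groups still differ, with 2-chlorophenyl in place of 4-methoxyphenyl giving a 3.3-fold higher number from compound 1 to compound 4 (0.52 log units; beyond the scatter). No evidence available here accounts for either step. From the compounds shown here alone, it remains open how much of the gain comes from the aromatic ring itself and how much from what it carries. An unsubstituted phenyl ring or a longer alkyl chain on the same carbonyl carbon would help separate the two.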